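Extending the octyl amide of compound 2 to an octadecyl chain

The source may report more compounds than this note shows. Statements on the series, on what has been measured and on what is new or still open speak of the compounds shown alone.

Two amides have been measured so far. Compound 1, with the structure `CCCCCCCCNC(=O)[C@@H](NC(=O)c1ccco1)[C@@H](C)O`, gives 64500 nM in a functional assay on A-431 cells (Homo sapiens) for cytotoxicity, read by MTT assay, with a stated time of 48 h; on this read-out higher numbers stand for weaker inhibition and lower numbers for stronger inhibition. Compound 2, with the structure `C/C=C/C=C/C(=O)N[C@H](C(=O)NCCCCCCCC)[C@@H](C)O`, gives 58200 nM in this assay, the lowest of the two numbers, though the step of a 1.1-fold lower number from compound 1 to compound 2 (0.04 log units; within the scatter) lies within the scatter, so the two compounds cannot be ranked. Compound 3, with the structure `C/C=C/C=C/C(=O)N[C@H](C(=O)NCCCCCCCCCCCCCCCCCC)[C@@H](C)O`, is not yet measured. It differs from compound 2 by decyl in place of hydrogen on a saturated chain carbon, eight bonds along the chain from an amide-type nitrogen. Among the compounds with values here, the only measured step concerns the group on the other carbonyl carbon and says nothing about the length of the amide chain, so no measured step bears on this change, and no direction can be argued from the data. Compound 3 is therefore estimated at 35000 nM in this assay, with a range from 8000 nM to 120000 nM, which means an expected step of a 1.7-fold lower number from compound 2 to compound 3 (0.22 log units; within the scatter).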

Compound 3, half-maximal inhibitory concentration: 187000 nM
Compound 3: the middle estimate sits 5.3-fold (0.73 log units) below what was measured, outside the stated range (above it).
By their numbers in this assay, from the lowest: compounds 2 and 1 (each within the scatter of the next); then compound 3.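

In this assay, the amide chain proves to be a position where the number can move: decyl in place of hydrogen on a saturated chain carbon, eight bonds along the chain from an amide-type nitrogen, gives a 3.2-fold higher number from compound 2 to compound 3 (0.51 log units; beyond the scatter). The earlier pair differed only in the group on the other carbonyl carbon and could not be ranked, so this is the first change among the compounds shown that separates two of them, and it goes towards weaker inhibition. Nothing at hand explains why the number rises with this change.

The compounds shown leave open how the number behaves between the octyl and octadecyl chains, for instance with a dodecyl chain, or with a chain shorter than octyl, such as butyl. They also leave open whether an amine or a carboxylic acid at the end of the chain would change the number, and whether the furan-2-yl amide would respond to the longer chain in the same way.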